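The compounds below may be only part of what the source reports. "The series", "measured", "known", "first", "only" and "open" are said of these compounds alone.

Compound 3 `CN(C)CCn1cnnc1-c1cc(Oc2ccc(NC(=O)N/N=C/c3cc(Br)c(O)c(Br)c3)cc2F)ccn1` gives 4320 nM in a functional assay on MKN-45 cells (Homo sapiens) for cytotoxicity, read by MTT assay, with a stated time of 72 h (a lower number here means a stronger inhibitor, a higher number a weaker inhibitor), the highest of the three numbers. Compound 2 `CN(C)CCn1cnnc1-c1cc(Oc2ccc(NC(=O)N/N=C/c3cc(C(C)(C)C)cc(C(C)(C)C)c3O)cc2F)ccn1` gives 3300 nM, within the scatter of compound 3, whereas compound 1 `CN(C)CCn1cnnc1-c1cc(Oc2ccc(NC(=O)N/N=C/c3ccc(Cl)cc3)cc2F)ccn1` gives 570 nM, and the step of a 7.6-fold higher number from compound 1 to compound 3 (0.88 log units; beyond the scatter) lies beyond the scatter. Compound 4 `COc1ccc(/C=N/NC(=O)Nc2ccc(Oc3ccnc(-c4nncn4CCN(C)C)c3)c(F)c2)cc1O` differs from compound 3 by 3-hydroxy-4-methoxyphenyl in place of 3,5-dibromo-4-hydroxyphenyl on a carbon with a double bond to nitrogen. Going by the values given here, no measured step exchanges one hydroxyphenyl for another at this carbon; the only step there is the one from compound 1 to compound 3. Since compound 2 and compound 3, both carrying a hydroxyl on that ring, sit together, the hydroxyl retained in compound 4 gives little ground for a large move. Compound 4 is therefore expected to show at most a small step, a 1.7-fold lower number from compound 3 to compound 4 (0.24 log units; within the scatter), and its number in this assay is estimated at 2500 nM, with a range from 800 nM to 8000 nM.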

Compound 4, half-maximal inhibitory concentration: 2510 nM
Compound 4: the middle estimate sits 1.0-fold (0.00 log units) below what was measured; measured number inside the range.
By their numbers in this assay, from the lowest: compound 1; then compounds 4, 2 and 3 (each within the scatter of the next).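

In this assay, 3-hydroxy-4-methoxyphenyl and 3,5-dibromo-4-hydroxyphenyl cannot be told apart on this carbon, with a 1.7-fold lower number from compound 3 to compound 4 (0.24 log units; within the scatter). The bromines are therefore not required for a number in this range, since a ring without them also stands apart from the 4-chlorophenyl of compound 1, with a 4.4-fold higher number from compound 1 to compound 4 (0.64 log units; beyond the scatter). No measurement here accounts for these numbers. The compounds shown leave open whether the hydroxyl itself separates these rings from the 4-chlorophenyl. They also leave open how an amine or a carboxylic acid on this ring would read.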